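The source may report more compounds than this note shows. Statements on the series, on what has been measured and on what is new or still open speak of the compounds shown alone.

The set rests on two cores. Compound 1 `COc1cc(/C=C2\CN(C)C/C(=C\c3ccccc3F)C2=O)cc(OC)c1` carries a 2-fluorophenyl on a double-bonded chain carbon bound to a double-bonded ring carbon; compound 2 `CN1C/C(=C\c2cccc([N+](=O)[O-])c2)C(=O)/C(=C/c2ccccc2F)C1` carries the same group on a second core, and the difference between the two cores is not broken down here. In a functional assay on THP-1 cells (Homo sapiens) for cytotoxicity, read by MTT assay, with a stated time of 24 h (a lower number here means a stronger inhibitor, a higher number a weaker inhibitor), compound 1 gives 1170 nM, and in this assay compound 2 gives 1010 nM; these two values lie within the scatter of each other, so nothing separates them. Compound 3 `COc1cc(/C=C2\CN(C)C/C(=C\c3ccc(F)cc3)C2=O)cc(OC)c1` arises from compound 1 by the change (4-fluorophenyl in place of 2-fluorophenyl on a double-bonded chain carbon bound to a double-bonded ring carbon), and in this assay compound 3 gives 5040 nM. The step of a 4.3-fold higher number from compound 1 to compound 3 (0.63 log units; beyond the scatter) lies beyond the scatter and is the only measured instance of this change among these compounds.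

Compound 4 `CN1C/C(=C\c2ccc(F)cc2)C(=O)/C(=C/c2cccc([N+](=O)[O-])c2)C1` stands to compound 2 as compound 3 stands to compound 1: 4-fluorophenyl in place of 2-fluorophenyl on a double-bonded chain carbon bound to a double-bonded ring carbon. The place is the same word for word, so it is the same change carried onto the second core. Whether the second core answers this change as the first does cannot be checked against any other pair here, so the expectation for compound 4 rests on a single precedent. Compound 4 is expected to show a step of the same direction and similar size, a 4.0-fold higher number from compound 2 to compound 4 (0.60 log units; beyond the scatter), because the same change gave a 4.3-fold higher number from compound 1 to compound 3 (0.63 log units; beyond the scatter) on the first core. Compound 4 is therefore estimated at 4000 nM in this assay, with a range from 1800 nM to 9000 nM.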

Compound 4, half-maximal inhibitory concentration: 7160 nM
Beside the measured number, compound 4's estimate is 1.8-fold (0.25 log units) below it; measured number inside the range.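

On the second core, 4-fluorophenyl in place of 2-fluorophenyl gives a 7.1-fold higher number from compound 2 to compound 4 (0.85 log units; beyond the scatter) in this assay, so the change moves the number in the same direction on both cores, and on each the step lies beyond the scatter. Set side by side, the two steps cannot be told apart, which means the change carries over from the first core to the second with no measurable difference in size: the same change on two cores in this assay, a 4.3-fold higher number (0.63 log units; beyond the scatter) from compound 1 to compound 3 and a 7.1-fold higher number (0.85 log units; beyond the scatter) from compound 2 to compound 4, 1.6-fold (0.22 log units) apart, within the scatter of two such steps. Among the compounds shown here, this rests on only two pairs of compounds in a single assay, so it does not show that the step would hold on any further core, it gives no ground for calling the step on the second core the greater of the two, and it does not explain why the 4-fluorophenyl compounds give the higher numbers.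

The compounds shown leave open whether a chlorophenyl, a methoxyphenyl or a pyridine ring in place of the fluorophenyl would follow the same trend on these two cores. They also leave open whether the step would survive on a core bearing an amine or a carboxylic acid on its other aromatic ring.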